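Adding a further methoxy to compound 3

A few compounds are considered here, and "the series" means these few. Any claim that something is new, unique, unknown or untested is made for them only; others in the source may bear on it.

Values measured in a functional assay on SW480 cells (Homo sapiens) for antiproliferative activity, read by sulforhodamine B assay, with a stated time of 48 h (on this read-out lower numbers stand for stronger inhibition and higher numbers for weaker inhibition), are these.
- compound 1 `COc1ccc(/C=C/C(=O)c2ccccc2-c2ccc(F)cc2)cc1` gives 61 nM
- compound 2 `COc1ccc(CNC(=O)c2ccccc2-c2ccc(F)cc2)cc1` gives > 50000 nM (a limit, not a number)
- compound 3 `COc1ccc(CNC(=O)c2ccccc2-c2ccc(F)cc2)cc1OC` gives > 50000 nM (a limit, not a number)

Compound 3 has no number in this assay and stands at > 50000 nM as a limit. The picture among these compounds is the limit of > 50000 nM in this assay, at which 2 of the 3 values shown sit, and only compound 1 reads as a number.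

Compound 4 `COc1cc(CNC(=O)c2ccccc2-c2ccc(F)cc2)cc(OC)c1OC` follows from compound 3 by the change methoxy in place of hydrogen on an aromatic carbon and so carries methoxy in place of hydrogen on an aromatic carbon. Within the data shown here, the one measured step of the same kind is a step that the two limits leave unreadable from compound 2 to compound 3 and it is the same replacement. Both of its ends are limits, so it gives neither a size nor a direction.

The expectation therefore rests on compound 3 at > 50000 nM as a limit, and no step beyond the scatter is expected in this assay in either direction. The expected step is a number no higher from compound 3 to compound 4 (the limit leaves the size open) as an estimate, and a further limit is the likeliest report. For compound 4 the estimated value is 50000 nM with 20000 nM to 100000 nM as the expected range.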

Compound 4, half-maximal inhibitory concentration: > 50000 nM
Compound 4: only a limit was reported; the forecaster's own chance of this, stated with the estimate: 85%; the middle value lies on the limit itself.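

In this assay compound 4 gives > 50000 nM, which is a limit and not a number. Compound 3 also stands at a limit, so no step can be read from compound 3 to compound 4: the limit of > 50000 nM in this assay, at which 3 of the 4 values shown sit.

The compounds shown leave open whether methoxy in place of hydrogen on an aromatic carbon has any effect in this assay.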